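The compounds below may be only part of what the source reports. "The series", "measured", "known", "first", "only" and "open" are said of these compounds alone.

Working notes on the series.

Compound 1 `CCOC(=O)c1sc(-c2cccc(NC(=O)c3ccc(C(F)(F)F)cc3)c2)nc1Nc1ccc(N2CCN(C)CC2)cc1` carries an ester on the shared core; in a functional assay on Raji cells (Homo sapiens) for antiproliferative activity, read by CCK-8 assay, with a stated time of 72 h (on this read-out lower numbers stand for stronger inhibition and higher numbers for weaker inhibition), compound 1 gives "not determined" (no result reported), so no result is reported for it. Going by the values given here, compound 2 `CN1CCN(c2ccc(Nc3nc(-c4cccc(NC(=O)c5ccc(C(F)(F)F)cc5)c4)sc3C(N)=O)cc2)CC1` carries the primary amide in its place and is the only member with a number: in this assay compound 2 gives 3210 nM. Among the compounds with values here, with a single value in hand, compound 2 stands alone, and no comparison between measured compounds is possible.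

Compound 3 `CN1CCN(c2ccc(Nc3nc(-c4cccc(NC(=O)c5ccccc5)c4)sc3C(N)=O)cc2)CC1` is the next entry to be measured. It differs from compound 2 in one place: hydrogen in place of trifluoromethyl on an aromatic carbon. The shared core, the primary amide and the piperazine-bearing aniline are unchanged.

Within the data shown here, no measured pair reports the effect of this change, so the expectation rests on compound 2 alone. The step from compound 2 to compound 3 is expected to be small, probably at the edge of the scatter or a modest loss, as in a 1.6-fold higher number from compound 2 to compound 3 (0.19 log units; within the scatter). For compound 3 the estimate in this assay is 5000 nM, with a range from 2000 nM to 15000 nM.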

Compound 3, half-maximal inhibitory concentration: 6360 nM
Estimate against measurement, compound 3: 1.3-fold (0.10 log units) below; the range from low to high includes it.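

Trifluoromethyl and hydrogen on this aromatic carbon, para to a large group, read alike within the scatter, with a 2.0-fold higher number from compound 2 to compound 3 (0.30 log units; within the scatter) in this assay. Going by these compounds alone, this is the first reading at this position: 4-(trifluoromethyl)phenyl can be exchanged for phenyl, with the 4 heavy atoms of trifluoromethyl leaving, and the step stays within the scatter, so these two compounds give no sign that the trifluoromethyl group is required for the read-out in this assay. No available data bear on why the two compounds read alike.

The compounds shown leave open whether another group on this aromatic carbon, such as a methoxy group, an amine or a carboxylic acid, would give a step beyond the scatter, since trifluoromethyl and hydrogen are the only two groups compared here. From the compounds shown here alone, the step from the ester of compound 1 to the primary amide of compound 2 cannot be read, so the contribution of the group at that place on the shared core remains open, as does that of a carboxylic acid or a nitrile there.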